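The source may hold more compounds than are shown below. What is called first, only, known or untested is meant among the compounds shown, and "the series" means these compounds.

Going by the values given here, only two compounds sharing one core have been measured so far. In a functional assay on HeLa cells (Homo sapiens) for cytotoxicity, read by MTT assay (on this read-out lower numbers stand for stronger inhibition and higher numbers for weaker inhibition), compound 1 (`CCC(O)CO[C@H](CC=C(C)C)C1=CC(=O)c2c(O)ccc(O)c2C1=O`) gives 28700 nM and compound 2 (`CC(=O)OC(C)CO[C@H](CC=C(C)C)C1=CC(=O)c2c(O)ccc(O)c2C1=O`) gives 40100 nM on the same read-out, which places compound 2 within the usual scatter of compound 1. Among the compounds with values here, the one measured step is a 1.4-fold higher number from compound 1 to compound 2 (0.15 log units; within the scatter) and it puts 1-acetoxyethyl in place of 1-hydroxypropyl on a saturated chain carbon bound to an oxygen on a saturated carbon. Compound 3 (`CC(C)=CC[C@@H](OC(=O)C1CCCO1)C1=CC(=O)c2c(O)ccc(O)c2C1=O`) has no number yet. Its difference from compound 2 reads (oxolan-2-yl)carbonyl in place of 2-acetoxypropyl on an oxygen on a saturated carbon and puts (oxolan-2-yl)carbonyl in place of 2-acetoxypropyl on an oxygen on a saturated carbon. Within the data shown here, only the one measured step bears on this change, and only loosely, since no measured compound carries (oxolan-2-yl)carbonyl. Among the measured compounds shown here, with a 1.4-fold higher number from compound 1 to compound 2 (0.15 log units; within the scatter) as the sole guide, no shift beyond the scatter is expected in this assay for this change, though the evidence is thin. The expected move is a 1.3-fold lower number from compound 2 to compound 3 (0.13 log units; within the scatter) on this estimate. Compound 3 is expected at about 30000 nM with an estimated range of 10000 nM to 70000 nM on this read-out.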

Compound 3, half-maximal inhibitory concentration: 17000 nM
Estimate against measurement, compound 3: 1.8-fold (0.25 log units) above; the measured number falls inside the stated range.
By their numbers in this assay, from the lowest: compounds 3, 1 and 2 (each within the scatter of the next, the first and the last beyond it).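

In this assay, putting (oxolan-2-yl)carbonyl in place of 2-acetoxypropyl on an oxygen on a saturated carbon gives a 2.4-fold lower number from compound 2 to compound 3 (0.37 log units; beyond the scatter) and so yields the one modest shift beyond the scatter among these compounds. Measured against 2-hydroxybutyl at the same oxygen, the same group gives a 1.7-fold lower number from compound 1 to compound 3 (0.23 log units; within the scatter) and therefore separates compound 3 from compound 2 only, not from compound 1. The counts of heavy atoms and hydrogen-bond acceptors stay the same in the step from 2-acetoxypropyl, while a five-membered non-aromatic ring enters, and no supporting measurement here says what lies behind the shift.

The step brings in the ring and places a carbonyl directly on the oxygen together, so the compounds shown cannot separate these two changes, which an open-chain pentanoyl group at this oxygen would bear on. Also open, as far as these compounds go, is how this oxygen tolerates other kinds of substituent, such as a benzoyl group, a 2-aminoethyl chain or a group carrying a carboxylic acid.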